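The compounds below may be only part of what the source reports. "The series", "measured", "known", "first", "only" and "open" are said of these compounds alone.

The series begins with compound 1 `O=C(Nc1ccc(Cl)c(-c2nnc3c(Cl)cccn23)c1)c1ccc(F)cc1Cl`, which in a functional assay on MCF7 cells (Homo sapiens) for antiproliferative activity, read by MTT assay, with a stated time of 72 h (a lower number here means a stronger inhibitor, a higher number a weaker inhibitor), gives only a limit of > 100000 nM, not a number. Compound 2 `Cc1nc(C(=O)Nc2ccc(Cl)c(-c3nnc4c(Cl)cccn34)c2)cs1` carries a 2-methyl-1,3-thiazol-4-yl group on the carbonyl carbon in place of the 2-chloro-4-fluorophenyl of compound 1. In this assay compound 2 likewise reaches only the limit of > 100000 nM. The step that the two limits leave unreadable from compound 1 to compound 2 therefore cannot be read, since both ends sit at the limit, as the limit of > 100000 nM in this assay, at which 2 of the 2 values shown sit, records. On the numbers shown, compound 2 stands at that limit with nothing to separate it from compound 1.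

Compound 3 `O=C(Nc1ccc(Cl)c(-c2nnc3c(Cl)cccn23)c1)c1ccc(Cl)cc1` differs from compound 2 by 4-chlorophenyl in place of 2-methyl-1,3-thiazol-4-yl on a carbonyl carbon. Among the compounds with values here, the only measured step, from compound 1 to compound 2, bears on this change and is of unreadable size, so it gives no direction. The closest comparison is compound 1, whose chlorinated phenyl ring already gave > 100000 nM as a limit. Compound 3 is accordingly expected to give about 150000 nM, with a range of 40000 nM to 600000 nM, which means an expected step that the limit leaves unreadable from compound 2 to compound 3, most likely again reported only as a limit.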

Compound 3, half-maximal inhibitory concentration: 58400 nM
Beside the measured number, compound 3's estimate is 2.6-fold (0.41 log units) above it; the measured number falls inside the stated range.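

Within the data shown here, on the carbonyl carbon whose other neighbour is the amide-type nitrogen, 4-chlorophenyl gives the only actual number among the three compounds, where the two earlier groups had left only limits. In this assay, the change from the thiazole reads as an at least 1.7-fold lower number from compound 2 to compound 3 (0.23 log units; that floor lies within the scatter), and the change from the other chlorinated phenyl group reads as an at least 1.7-fold lower number from compound 1 to compound 3 (0.23 log units; that floor lies within the scatter). Both steps are floors that do not pass the usual scatter, so this position is shown to allow a measurable value, but no gain in potency is established, and each step stays tied to a limit: the limit of > 100000 nM in this assay, at which 2 of the 3 values shown sit.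

The compounds shown leave open what the single chlorine on the ring contributes, and a plain phenyl or a 4-methoxyphenyl on the same carbonyl carbon would speak to that. Also open, from the compounds shown here alone, is whether the value of compound 3 can be moved further, whether by a carboxylic acid or a saturated amine such as a piperidine on that ring, or by a change elsewhere on the shared core.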